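Linker swap at the aminopyrrolidine position of compound 1

A few compounds are considered here, and "the series" means these few. Any claim that something is new, unique, unknown or untested is made for them only; others in the source may bear on it.

Measured compounds:
compound 1 `N[C@@H]1CCN(c2cc3c(cc2F)c(=O)c(C(=O)O)cn3Cc2ccc(-c3ccccc3)cc2)C1` — 63600 nM
compound 2 `COc1c(N2CC[C@@H](CO)C2)c(F)cc2c(=O)c(C(=O)O)cn(Cc3ccc(-c4ccccc4)cc3)c12` — > 200000 nM
compound 3 `COc1c(N2CC[C@@H](N)C2)c(F)cc2c(=O)c(C(=O)O)cn(Cc3ccc(-c4ccccc4)cc3)c12` — 92200 nM

In an assay on isolated protein for inhibition of DNA topoisomerase 1 (Homo sapiens), with a stated time of 15 min (on this read-out lower numbers stand for stronger inhibition and higher numbers for weaker inhibition), compound 1 stands at the lowest of the two numbers shown; its nearest neighbour is compound 3, and a 1.4-fold higher number from compound 1 to compound 3 (0.16 log units; within the scatter) lies within the scatter. For compound 2 the read-out is a limit, (the limit of > 200000 nM in this assay, at which 1 of the 3 values shown sits). Compound 4 `O=C(O)c1cn(Cc2ccc(-c3ccccc3)cc2)c2cc(NC[C@@H]3CCNC3)c(F)cc2c1=O` is not yet measured; it differs from compound 1 by ((pyrrolidin-3-yl)methyl)amino in place of 3-aminopyrrolidin-1-yl on an aromatic carbon. Neither measured step tests this kind of change: a 1.4-fold higher number from compound 1 to compound 3 (0.16 log units; within the scatter) concerns a methoxy group, and an at least 2.1-fold lower number from compound 2 to compound 3 (0.33 log units; beyond the scatter) exchanges amino for hydroxymethyl on the saturated ring while the ring keeps its attachment. With the amino-bearing pyrrolidine retained but re-attached through a methylene and an amino link, no step beyond the scatter is expected in this assay. Compound 4 is therefore expected to give about 80000 nM, within 30000 nM to 200000 nM, an estimated step of a 1.3-fold higher number from compound 1 to compound 4 (0.10 log units; within the scatter).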

Compound 4, half-maximal inhibitory concentration: 104000 nM
The estimate for compound 4 lay 1.3-fold (0.11 log units) below the measured number; low and high end bracket the measured number.
By their numbers in this assay, from the lowest: compounds 1, 3 and 4 (each within the scatter of the next). At a limit, above all of these: compound 2.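

Replacing 3-aminopyrrolidin-1-yl with ((pyrrolidin-3-yl)methyl)amino on this aromatic carbon, ortho to a fluoro group, gives no change beyond the scatter in this assay: a 1.6-fold higher number from compound 1 to compound 4 (0.21 log units; within the scatter). The attachment through the pyrrolidine ring nitrogen is therefore not required at this position, since a secondary amino link with one more heavy atom is tolerated on the core of compound 1. Nothing shown accounts for this outcome.

Open, as far as these compounds go, is how an open-chain group such as 2-aminoethylamino, or a six-membered piperazine, would read at this carbon. Also open, from the compounds shown here alone, is the effect of the opposite stereocentre in the ((pyrrolidin-3-yl)methyl)amino group.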